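The source may hold more compounds than are shown below. What is called first, only, known or untested is meant among the compounds shown, and "the series" means these compounds.

In an assay on Sf9 cells for inhibition of sphingosine-1-phosphate lyase 1 (Homo sapiens), with a stated time of 1 h (a higher number here means a weaker inhibitor, a lower number a stronger inhibitor), compound 2, whose structure is `C[C@@H]1CN(c2nnc(Cc3ccccc3)c3ccccc23)CCN1c1ccc(C(F)(F)F)cn1`, gives 30000 nM. Within the data shown here, that is the higher of the two numbers measured so far, so compound 2 is the weaker inhibitor of the pair. Its nearest neighbour is compound 1, with the structure `CCOC(=O)c1ccc(N2CCN(c3nnc(Cc4ccccc4)c4ccccc34)C[C@H]2C)nc1`, which in this assay gives 3400 nM. Among the measured compounds shown here, the one measured step, an 8.8-fold higher number from compound 1 to compound 2 (0.95 log units; beyond the scatter), replaced an ethoxycarbonyl group with a trifluoromethyl group and raised the number well beyond the scatter. Compound 3, whose structure is `C[C@@H]1CN(c2nnc(Cc3ccccc3)c3ccccc23)CCN1c1ccc([N+](=O)[O-])cn1`, is not yet measured. It differs from compound 2 in one place: nitro in place of trifluoromethyl on an aromatic carbon. For the measured compounds named here, no measured step covers this exchange directly, and the only step available describes the move away from compound 1 rather than towards a nitro group, so it bears on the question only loosely. On that thin basis, compound 3 is estimated to give a somewhat lower number than compound 2, with the expected step being a 2.5-fold lower number from compound 2 to compound 3 (0.40 log units; beyond the scatter), though a result within the scatter would not surprise. The estimate for compound 3 in this assay is 12000 nM, with a range from 3000 nM to 50000 nM.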

Compound 3, half-maximal inhibitory concentration: 740 nM
The estimate for compound 3 lay 16-fold (1.21 log units) above the measured number, and the stated range ends above it.
By their numbers in this assay, from the lowest: compound 3; then compound 1; then compound 2.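

In this assay, the earlier step showed only that replacing ethoxycarbonyl with trifluoromethyl gave a higher number; the 5-nitropyridin-2-yl group now shows that a change at this same position can also give a much lower one (a 41-fold lower number from compound 2 to compound 3 (1.61 log units; beyond the scatter)). The nitro group also improves on the ethoxycarbonyl group (a 4.6-fold lower number from compound 1 to compound 3 (0.66 log units; beyond the scatter)), so compound 3 is the strongest inhibitor of the three, and all three gaps lie beyond the scatter. The position is therefore sensitive to which group it carries, and the large spread comes from exchanges at a single aromatic carbon, with the rest of the molecule held constant, although nothing available explains why nitro gives the lowest number of the three.

Among these compounds, with only three groups compared, it remains open whether nitro is unusual here or whether a nitrile, a primary amide or a carboxylic acid at this position would give a similar or even lower number. As far as these compounds go, all three compounds also share the same core, so it is unknown whether this order of groups would hold on a different one.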